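Extending the methyl of compound 3 with oxetan-3-yl

A few compounds are considered here, and "the series" means these few. Any claim that something is new, unique, unknown or untested is made for them only; others in the source may bear on it.

- compound 1 `Cc1nc(N[C@H](C)c2cccc(C(F)F)c2F)c2cc3c(cc2n1)OCC[C@H]1CN(C(=O)C2COC2)CCN31` gives 1630 nM
- compound 2 `Cc1nc(N[C@H](C)c2cccc(C(F)F)c2F)c2cc3c(cc2n1)OCC[C@H]1CN(C(=O)c2cccnc2)CCN31` gives 2810 nM
- compound 3 `Cc1nc(N[C@H](C)c2cccc(C(F)F)c2F)c2cc3c(cc2n1)OCC[C@H]1CN(C)CCN31` gives 405 nM

Compound 3 stands lowest of the three in an ADME assay on the whole organism (Mus musculus, strain ICR) for pharmacokinetics, read by LC-MS, with a stated time of 24 h, at a dose of 50 mg/kg by the oral route; a higher number here means more compound in the circulation at the dose given, a lower number less compound in the circulation. In compound 4 `Cc1nc(N[C@H](C)c2cccc(C(F)F)c2F)c2cc3c(cc2n1)OCC[C@H]1CN(CC2COC2)CCN31`, oxetan-3-yl takes the place of hydrogen on a saturated chain carbon bound to an amine nitrogen in a ring (oxetan-3-yl in place of hydrogen on a saturated chain carbon bound to an amine nitrogen in a ring). Within the data shown here, two measured steps bear on this only in part: a 4.0-fold lower number from compound 1 to compound 3 (0.60 log units; beyond the scatter) and a 6.9-fold lower number from compound 2 to compound 3 (0.84 log units; beyond the scatter). Both replace a carbonyl-bearing group with methyl, whereas compound 4 has no carbonyl. Among the measured compounds shown here, no measured step adds oxetan-3-yl to that methyl. A small upward change in this assay is therefore expected, possibly not beyond the scatter, with the expected step being a 1.7-fold higher number from compound 3 to compound 4 (0.24 log units; within the scatter). The estimate for compound 4 is 700 nM, with an expected range of 250 nM to 1800 nM.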

Compound 4, maximal plasma concentration: 1220 nM
Compound 4: middle estimate off by 1.7-fold (0.24 log units), on the low side; low and high end bracket the measured number.
By their numbers in this assay, from the lowest: compound 3; then compounds 4, 1 and 2 (each within the scatter of the next, the first and the last beyond it).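

With (oxetan-3-yl)methyl on the amine nitrogen in a ring, this assay gives a 3.0-fold higher number from compound 3 to compound 4 (0.48 log units; beyond the scatter), so a rise over methyl does not require a carbonyl. Losing the carbonyl from the oxetane side chain leaves a 1.3-fold lower number from compound 1 to compound 4 (0.13 log units; within the scatter), whereas the pyridin-3-yl amide keeps a margin, with a 2.3-fold lower number from compound 2 to compound 4 (0.36 log units; beyond the scatter). Nothing available explains these steps.

Still open, as far as these compounds go, is whether the oxetan-3-yl ring itself matters or any group on that methyl would serve. A cyclobutyl or a longer chain in its place would separate the two.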